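The source may hold more compounds than are shown below. What is called first, only, known or untested is meant among the compounds shown, and "the series" means these compounds.

Measured compounds:
- compound 1 `Cc1cc(COc2cccc(C#N)c2)nc(-c2ccccn2)n1`: 2510 nM
- compound 2 `CCNc1cc(COc2cccc(F)c2)nc(-c2ccccn2)n1`: 631 nM
- compound 3 `CC1(CS(C)(=O)=O)CN(c2cc(COc3ccc(F)c(F)c3F)nc(-c3ccccn3)n2)C1`: 6310 nM

In a functional assay on cells for antagonist activity at Free fatty acid receptor 1 (Homo sapiens), read by TR-FRET and inositol phosphate accumulation, with a stated time of 2 h (a lower number here means a stronger inhibitor, a higher number a weaker inhibitor), compound 3 gives 6310 nM, the highest of the three numbers. Its nearest neighbour is compound 1 with 2510 nM, a gap beyond the scatter; compound 2 lies furthest away with 631 nM, also beyond the scatter. Within the data shown here, no pair of the three differs in a single place, so these gaps cannot be tied to one structural change.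

Compound 4 `N#CCC1(COc2cc(COc3ccc(F)c(F)c3F)nc(-c3ccccn3)n2)COC1` is not yet measured in this assay. It differs from compound 3 in one place: (3-(cyanomethyl)oxetan-3-yl)methoxy in place of 3-methyl-3-((methylsulfonyl)methyl)azetidin-1-yl on an aromatic carbon. Among the measured compounds shown here, nothing among the measured compounds tells how this substitution on the shared core shifts the read-out, since no other pair varies the same position alone. For the measured compounds named here, with no comparable step to lean on, the expectation is a change of modest size, within or close to the scatter, and no firm direction. The step from compound 3 to compound 4 is estimated at a 1.4-fold lower number from compound 3 to compound 4 (0.15 log units; within the scatter). For compound 4 the expected value in this assay is 4500 nM, with a range from 1300 nM to 15000 nM.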

Compound 4, half-maximal inhibitory concentration: 398 nM
Estimate against measurement, compound 4: 11-fold (1.05 log units) above; the whole stated range lies above it.
By their numbers in this assay, from the lowest: compounds 4 and 2 (each within the scatter of the next); then compound 1; then compound 3.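

In this assay the exchange of 3-methyl-3-((methylsulfonyl)methyl)azetidin-1-yl for (3-(cyanomethyl)oxetan-3-yl)methoxy on this aromatic carbon gives a 16-fold lower number from compound 3 to compound 4 (1.20 log units; beyond the scatter) and counts as a large step. Among these compounds, the read-out at this position is therefore sensitive to the group it carries, with the (2,3,4-trifluorophenoxy)methyl and pyridin-2-yl groups held constant, which the earlier compounds could not show without a single-place pair. No measurement at hand accounts for the size of this step.

Which part of the entering group matters remains open: the methoxy link, the four-membered ring or the cyanomethyl group. Also open, from the compounds shown here alone, is how this position would respond to a carboxylic acid or a longer alkoxy chain.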